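Swapping the fluorobenzyl arm for a hydroxypropyl chain

The source may hold more compounds than are shown below. What is called first, only, known or untested is meant among the compounds shown, and "the series" means these compounds.

Two compounds have so far been run in an assay on membranes from striatum (strain Sprague-Dawley) for displacement of a labelled ligand from sodium-dependent dopamine transporter (Rattus norvegicus), read by scintillation counting, with a stated time of 120 min; on this read-out lower numbers stand for stronger inhibition and higher numbers for weaker inhibition. Compound 1 `Fc1ccc(CN2CCC(NCCSC(c3ccc(F)cc3)c3ccc(F)cc3)CC2)cc1` gives 25.5 nM, and compound 2 `[O-][S+](CCNC1CCN(Cc2ccc(F)cc2)CC1)C(c1ccc(F)cc1)c1ccc(F)cc1` gives 50.6 nM; the two numbers lie within the scatter of each other, so neither stands apart from the other in this assay. Compound 3 `OC(Cc1ccccc1)CN1CCC(NCCSC(c2ccc(F)cc2)c2ccc(F)cc2)CC1` has not yet been measured. It is reached from compound 1 by the change (1-hydroxy-2-phenylethyl in place of 4-fluorophenyl on a saturated chain carbon bound to an amine nitrogen in a ring). Within the data shown here, no measured pair shows this change, so there is no step to lean on, only the values of compound 1 and compound 2 as a frame. The estimate for compound 3 is that the step of a 1.6-fold higher number from compound 1 to compound 3 (0.20 log units; within the scatter) stays small, running a little toward weaker inhibition without going beyond the usual scatter. Compound 3 is therefore expected to give about 40 nM in this assay, with a likely range from 12 nM to 130 nM.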

Compound 3, inhibition constant: 31.4 nM
Estimate against measurement, compound 3: 1.3-fold (0.11 log units) above; low and high end bracket the measured number.
By their numbers in this assay, from the lowest: compounds 1, 3 and 2 (each within the scatter of the next).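

The step of a 1.2-fold higher number from compound 1 to compound 3 (0.09 log units; within the scatter) in this assay shows that a substantial exchange can be made on a saturated chain carbon bound to an amine nitrogen in a ring without the number moving beyond the scatter. The 2-hydroxy-3-phenylpropyl arm loses the fluorine of 4-fluorobenzyl and brings one hydrogen-bond donor and one hydrogen-bond acceptor, yet this single pair gives no sign that either difference shifts binding at the dopamine transporter. No evidence here accounts for the small size of the step.

This one step merges all the differences between the two arms, so the separate contributions of the hydroxyl, the extra chain atoms and the fluorine remain unresolved. Also open, on these data alone, is how this position would respond to an amine or a carboxylic acid in place of the hydroxyl, or to a longer chain.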